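Sulfur for oxygen on a butyl carbamate nucleoside

The source may report more compounds than this note shows. Statements on the series, on what has been measured and on what is new or still open speak of the compounds shown alone.

Compound 1 `CCCNC(=O)OC[C@H]1OC(n2cnc3c(NC4CCOC4)ncnc32)[C@H](O)[C@@H]1O` gives 235 nM in an assay on DDT1 cells (Cricetulus griseus) for binding affinity to adenosine receptor A1 (Homo sapiens), read by radioligand binding; a higher number here means a weaker inhibitor, a lower number a stronger inhibitor.
Compound 2 `CCC/N=C(\S)OC[C@H]1OC(n2cnc3c(NC4CCOC4)ncnc32)[C@H](O)[C@@H]1O` gives 50 nM in this assay.
Compound 3 `CCCCNC(=O)OC[C@H]1OC(n2cnc3c(NC4CCOC4)ncnc32)[C@H](O)[C@@H]1O` gives 1410 nM in this assay.

Compound 3 is the weakest inhibitor of the three: its number is the highest, and both gaps separating it from the others lie beyond the scatter, a 6.0-fold higher number from compound 1 to compound 3 (0.78 log units; beyond the scatter) and a 28-fold higher number from compound 2 to compound 3 (1.45 log units; beyond the scatter).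

Compound 4 `CCCC/N=C(\S)OC[C@H]1OC(n2cnc3c(NC4CCOC4)ncnc32)[C@H](O)[C@@H]1O` is the not yet measured partner of compound 3. It differs by a group of 7 heavy atoms (5 carbon, 1 nitrogen, 1 sulfur; no ring) in place of a group of 7 heavy atoms (5 carbon, 1 nitrogen, 1 oxygen; no ring), on an oxygen on a saturated carbon. The closest guide is the step in which the same sulfur-for-oxygen exchange was made on the shorter, propyl chain: a 4.7-fold lower number from compound 1 to compound 2 (0.67 log units; beyond the scatter). That step lowered the number by a modest amount, beyond the scatter. Within the data shown here, nothing measured here speaks against carrying the same shift over to the longer chain, although only one such pair exists and the butyl series may not follow it exactly.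

On that basis compound 4 is expected to bind more tightly than compound 3, with a step of about a 4.7-fold lower number from compound 3 to compound 4 (0.67 log units; beyond the scatter). The estimate for compound 4 in this assay is 300 nM, with a likely range from 100 nM to 900 nM.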

Compound 4, inhibition constant: 157 nM
The estimate for compound 4 lay 1.9-fold (0.28 log units) above the measured number, within the range that was stated.
By their numbers in this assay, from the lowest: compound 2; then compounds 4 and 1 (each within the scatter of the next); then compound 3.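

The sulfur-for-oxygen exchange now has a second pair behind it: in this assay it gives a 9.0-fold lower number from compound 3 to compound 4 (0.95 log units; beyond the scatter) on the butyl chain, so the lower number seen with a 4.7-fold lower number from compound 1 to compound 2 (0.67 log units; beyond the scatter) on the propyl chain is not confined to that one chain length. Lengthening the chain by one methyl also raises the number in the sulfur series, with a 3.1-fold higher number from compound 2 to compound 4 (0.50 log units; beyond the scatter), yet the two changes made together leave little net difference, with a 1.5-fold lower number from compound 1 to compound 4 (0.18 log units; within the scatter). The penalty for the longer chain looks much the same whether oxygen or sulfur is present, which suggests that at this position the chain length and the exchange act largely independently of each other: the same change on two cores in this assay, a 6.0-fold higher number (0.78 log units; beyond the scatter) from compound 1 to compound 3 and a 3.1-fold higher number (0.50 log units; beyond the scatter) from compound 2 to compound 4, 1.9-fold (0.28 log units) apart, within the scatter of two such steps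

The compounds shown leave open whether both trends continue on an ethyl or a pentyl chain, or hold when a cyclopentyl group replaces the straight chain. With the rest of the core held fixed throughout, they also cannot tell whether the sulfur exchange would lower the number in the same way with a different amine on the core.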